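The compounds below may be only part of what the source reports. "The series", "measured", "known", "first", "only" and "open" are said of these compounds alone.

Compound 1 `COc1cc(-n2c(-c3ccccc3)csc2=S)cc(OC)c1OC` is tested in a functional assay on MCF7 cells (Homo sapiens) for cytotoxicity, read by MTT assay, with a stated time of 48 h; on this read-out higher numbers stand for weaker inhibition and lower numbers for stronger inhibition. In this assay compound 1 gives only a limit, > 100 ug/mL, so its position is known only as a bound (the limit of > 100 ug/mL in this assay, at which 1 of the 2 values shown sits). Compound 2 `COc1cc(-n2c(-c3ccc(C)cc3)csc2=S)cc(OC)c1OC` carries a methyl on the aromatic ring and gives in this assay 19.7 ug/mL. For the measured compounds named here, the one measured step, an at least 5.0-fold lower number from compound 1 to compound 2 (0.70 log units; beyond the scatter), shows that a change on that ring can move the number beyond the scatter. Compound 3 `COc1cc(-n2c(-c3ccc(O)c(O)c3)csc2=S)cc(OC)c1OC` differs from compound 1 by 3,4-dihydroxyphenyl in place of phenyl on an aromatic carbon. Going by the values given here, the step from compound 1 to compound 2 is the only measured step that bears on this change, and it points toward a lower number; on that basis a step of similar or larger size is expected, an at least 2.8-fold lower number from compound 1 to compound 3 (0.45 log units; beyond the scatter). Compound 3 is therefore estimated to give about 35 ug/mL in this assay, with a plausible range from 10 ug/mL to 100 ug/mL.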

Compound 3, half-maximal inhibitory concentration: > 100 ug/mL
Compound 3 gave a limit, no number; the forecaster's own chance of this, stated with the estimate: 30%; middle value at least 2.8-fold (0.45 log units) from the limit.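

In this assay, the lower number seen with 4-methylphenyl on this aromatic carbon does not carry over to 3,4-dihydroxyphenyl: an at least 5.0-fold higher number from compound 2 to compound 3 (0.70 log units; beyond the scatter). A substituted phenyl at this place is therefore not enough on its own to lower the number, and of the three compounds only compound 2 gives a number rather than a limit. The step between compound 1 and compound 3 cannot be read, as each of the two compounds gives only a limit: the limit of > 100 ug/mL in this assay, at which 2 of the 3 values shown sit.

The compounds shown leave open how compound 1 and compound 3 differ from each other. They also leave open whether an ethyl, a methoxy or a chloro group in place of the methyl of compound 2 would keep the lower number.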